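From a 2-Chlorophenyl to a 3-Fluorophenyl Group

A few compounds are considered here, and "the series" means these few. Any claim that something is new, unique, unknown or untested is made for them only; others in the source may bear on it.

Measured so far:
- compound 1, `COc1cccc(N2CCN(C(=O)C(C)N3C(=O)CCC3=O)CC2)c1`: 75%
- compound 2, `CC(C(=O)N1CCN(c2ccc(Cl)cc2)CC1)N1C(=O)CCC1=O`: 100%
- compound 3, `CCC(C(=O)N1CCN(c2ccccc2Cl)CC1)N1C(=O)CCC1=O`: 50%

All three share one core and were tested in a functional assay on the whole organism (strain Swiss) with Mus musculus as the target, in the maximal electroshock model, with a stated time of 0.25 h, at a dose of 300 mg/kg by the intraperitoneal route; on this read-out higher numbers stand for a stronger effect at the one dose given and lower numbers for a weaker effect. Compound 3 stands lowest of the three numbers: compound 1 lies above it by a margin beyond the scatter, and compound 2 lies further above it, also beyond the scatter.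

The next compound, compound 4, `CCC(C(=O)N1CCN(c2cccc(F)c2)CC1)N1C(=O)CCC1=O`, is not yet measured. It differs from compound 3 in one place: 3-fluorophenyl in place of 2-chlorophenyl on an amine nitrogen in a ring.

Within the data shown here, only one measured step touches the same place, the exchange of the aromatic group on the ring nitrogen: a number 25 percentage points higher from compound 1 to compound 2 (beyond the scatter). Among the measured compounds shown here, that step shows that a swap of this group alone can move the read-out in this assay by a modest amount, though it does not involve either of the two groups exchanged here, and no measured pair separates the effect of a fluorine from that of a chlorine on that ring.

Given that the one related step was an increase, compound 4 is expected to give 75% in this assay, with a range from 40% to 100%. For the measured compounds named here, this means an estimated step of a number 25 percentage points higher from compound 3 to compound 4 (beyond the scatter), a size comparable to the one measured step, but with wide uncertainty since compound 3 is the lowest of the measured numbers and no measured step here is smaller than the scatter.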

Compound 4, a percentage reported as activity, at one dose (the size of the read-out at that dose, not a potency): 75%
Beside the measured number, compound 4's estimate shows no gap at the digits printed, within the range that was stated.
By their numbers in this assay, from the lowest: compound 3; then compounds 1 and 4 (each within the scatter of the next); then compound 2.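

In this assay, the exchange of 2-chlorophenyl for 3-fluorophenyl on the amine nitrogen in a ring gives a number 25 percentage points higher from compound 3 to compound 4 (beyond the scatter), so this place also responds on the core of compound 3, not only on the core of compound 1, where the earlier step was a number 25 percentage points higher from compound 1 to compound 2 (beyond the scatter). The two groups have the same count of heavy atoms, the same aromatic ring and no hydrogen-bond donors or acceptors, so these counts do not tell them apart, yet the read-out still moves beyond the scatter, and this single step changes both the halogen and its place on the ring. No measured evidence shown here accounts for the size or direction of this step.

From the compounds shown here alone, how much of the step belongs to the halogen and how much to its place on the ring stays open, and a 3-chlorophenyl or 2-fluorophenyl group on the same core would separate the two. Also open, going by these compounds, is how an unsubstituted phenyl or a 3-methoxyphenyl group on this core would compare with compound 3 and compound 4.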